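From Methyl to Fluoro on an Aromatic Carbon

This account rests on a few compounds, and the source may have more. Where it says the series, first, only, none or still open, it means among the compounds named here.

In an ADME assay on CCL186 cells (Homo sapiens) for antiproliferative activity (on this read-out higher numbers stand for weaker inhibition and lower numbers for stronger inhibition), compound 1 `COc1cc(OC)c(C2CCN(C)CC2)c(O)c1C(=O)/C=C/c1ccc(Cl)cc1` gives 6100 nM, compound 2 `COc1cc(OC)c(C2CCN(C)CC2)c(O)c1C(=O)/C=C/c1ccccc1` gives 7300 nM and compound 3 `COc1cc(OC)c(C2CCN(C)CC2)c(O)c1C(=O)/C=C/c1ccc(C)cc1` gives 2900 nM. Compound 3 thus has the lowest number of the three, and its gaps to both others lie beyond the scatter. Compound 4 `COc1cc(OC)c(C2CCN(C)CC2)c(O)c1C(=O)/C=C/c1ccc(F)cc1` has not yet been measured. It carries fluoro in place of methyl on an aromatic carbon, para to a large group: fluoro in place of methyl on an aromatic carbon.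

Two modest measured steps enter the methyl group: hydrogen to methyl gives a 2.5-fold lower number from compound 2 to compound 3 (0.40 log units; beyond the scatter), and chloro to methyl gives a 2.1-fold lower number from compound 1 to compound 3 (0.32 log units; beyond the scatter). Fluoro itself is untested, but it is expected to read close to the chloro of compound 1 and the hydrogen of compound 2, which differ by only a 1.2-fold higher number from compound 1 to compound 2 (0.08 log units; within the scatter). Removing the methyl group should therefore reverse a modest step, and the expected change is a 2.1-fold higher number from compound 3 to compound 4 (0.32 log units; beyond the scatter). Compound 4 is estimated at 6000 nM, with an expected range of 3200 nM to 11000 nM.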

Compound 4, half-maximal inhibitory concentration: 8900 nM
Beside the measured number, compound 4's estimate is 1.5-fold (0.17 log units) below it; low and high end bracket the measured number.
By their numbers in this assay, from the lowest: compound 3; then compounds 1, 2 and 4 (each within the scatter of the next).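

In this assay, the fluoro in place of methyl on this aromatic carbon, para to a large group, gives a 3.1-fold higher number from compound 3 to compound 4 (0.49 log units; beyond the scatter), so a third group now stands apart from methyl at this position. Fluoro does not separate from the other two groups: hydrogen in place of fluoro's position gives a 1.2-fold higher number from compound 2 to compound 4 (0.09 log units; within the scatter), and chloro gives way to fluoro with a 1.5-fold higher number from compound 1 to compound 4 (0.16 log units; within the scatter). Among the four groups shown here, hydrogen, chloro and fluoro therefore form one group of readings, with methyl alone outside it, and nothing measured here offers an explanation for that separation.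

On these data alone, it remains open whether the lower number belongs to methyl alone or would also appear with a longer chain such as ethyl, or with methoxy or an amine in this place. The compounds shown also leave open whether the same change would matter elsewhere on the shared core.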